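Amide cap variation on the shared chalcone core

The source may report more compounds than this note shows. Statements on the series, on what has been measured and on what is new or still open speak of the compounds shown alone.

Measured compounds and their values in a functional assay on U-87MG ATCC cells (Homo sapiens) for inhibition; on this read-out higher numbers stand for weaker inhibition and lower numbers for stronger inhibition:
compound 1 `COc1cc(/C=C/C(=O)c2cccc(NC(=O)c3ccco3)c2)ccc1O` gives 6.65 ug/mL
compound 2 `COc1cc(/C=C/C(=O)c2cccc(NC(=O)c3ccccc3)c2)ccc1O` gives 8.82 ug/mL
compound 3 `COc1cc(/C=C/C(=O)c2cccc(NC(=O)c3c(Cl)cccc3Cl)c2)ccc1O` gives 17.8 ug/mL

Compound 3 has the highest number of the three; its gap to compound 2 stays within the scatter, while the step of a 2.7-fold higher number from compound 1 to compound 3 (0.43 log units; beyond the scatter) lies beyond it. Compound 4 `COc1cc(/C=C/C(=O)c2cccc(NC(C)=O)c2)ccc1O` differs from compound 3 as follows: methyl in place of 2,6-dichlorophenyl on a carbonyl carbon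

Going by the values given here, the steps that bear on this change are a 2.0-fold higher number from compound 2 to compound 3 (0.30 log units; within the scatter) and a 2.7-fold higher number from compound 1 to compound 3 (0.43 log units; beyond the scatter): the two smaller caps on the carbonyl carbon gave lower numbers than 2,6-dichlorophenyl. Methyl is smaller still, so a step back down towards the numbers of compound 1 and compound 2 is expected, a 2.1-fold lower number from compound 3 to compound 4 (0.32 log units; beyond the scatter), though acetyl has no measured neighbour here. Compound 4 is estimated at 8.5 ug/mL, within 3.5 ug/mL to 22 ug/mL.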

Compound 4, half-maximal inhibitory concentration: > 50 ug/mL
Compound 4: no number, only a limit; the forecaster's own chance of this, stated with the estimate: 5%; middle value at least 5.8-fold (0.76 log units) from the limit.
By their numbers in this assay, from the lowest: compounds 1, 2 and 3 (each within the scatter of the next, the first and the last beyond it). At a limit, above all of these: compound 4.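

In this assay compound 4 gives > 50 ug/mL, which is a limit of the assay and not a number. Methyl on this carbonyl carbon raises the number from each ring-bearing cap: an at least 2.8-fold higher number from compound 3 to compound 4 (0.44 log units; beyond the scatter), an at least 5.6-fold higher number from compound 2 to compound 4 (0.75 log units; beyond the scatter) and an at least 7.5-fold higher number from compound 1 to compound 4 (0.87 log units; beyond the scatter). The earlier compounds shown here all carry a ring here, so they could not show that the lower numbers of furan-2-yl and phenyl do not extend to methyl.

Open, going by these compounds, is whether a longer chain such as propyl, or a cyclohexyl cap, returns to the numbers of the ring-bearing caps. On these data alone, the full size of these steps also stays open, since compound 4 has only a limit.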